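A few compounds are considered here, and "the series" means these few. Any claim that something is new, unique, unknown or untested is made for them only; others in the source may bear on it.

Compound 1, `CCCCCCCCCCCCCC[C@H](O)[C@H](CO[Si](c1ccccc1)(c1ccccc1)C(C)(C)C)NC(=O)OC(C)(C)C`, gives 14.6% in a functional assay on A549 cells (Homo sapiens) for antiproliferative activity, read by sulforhodamine B assay, with a stated time of 48 h, tested at 10 uM; a higher number here means more inhibition at the concentration tested (going by the name of the read-out), a lower number less inhibition.
Compound 2, `CCCCCCCCCCCCCC[C@H](OCOC)[C@H](CO[Si](c1ccccc1)(c1ccccc1)C(C)(C)C)NC(=O)OC(C)(C)C`, gives 15.1% in this assay.
Compound 3, `CCCCCCCCCCCCCC[C@H](OCOC)[C@H](CN(CC)CC)NC(=O)OC(C)(C)C`, gives 27.5% in this assay.

Compound 2 and compound 1 share a core and differ at one place, (hydrogen in place of methoxymethyl on an oxygen on a saturated carbon); the step between them is a number 0.5 percentage points lower from compound 2 to compound 1 (within the scatter). Compound 3 carries a different core, and the difference between the core of compound 3 and the core of compound 2 is not broken down here. Among the three measured compounds, compound 3 stands highest in this assay, with both compound 2 and compound 1 lying beyond the scatter below it.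

Compound 4, `CCCCCCCCCCCCCC[C@H](O)[C@H](CN(CC)CC)NC(=O)OC(C)(C)C`, has not yet been measured. It differs from compound 3 by hydrogen in place of methoxymethyl on an oxygen on a saturated carbon. Within the data shown here, this is the same change as the one that turns compound 2 into compound 1, made on the core of compound 3 rather than on the core of compound 2; the surroundings of the place are the same in both pairs.

Among the measured compounds shown here, the expectation for compound 4 rests on the single earlier example of this change: the step from compound 3 to compound 4 in this assay is estimated at a number 0.5 percentage points lower from compound 3 to compound 4 (within the scatter), a small step because a number 0.5 percentage points lower from compound 2 to compound 1 (within the scatter) was small. Compound 4 is therefore expected to give about 27% in this assay, with a likely range from 17% to 37%.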

Compound 4, a percentage reported as inhibition, at one concentration (the size of the read-out at that concentration, not a potency): 18.5%
Beside the measured number, compound 4's estimate is 8.5 percentage points above it, and the stated range covers the measured number.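

In this assay, replacing methoxymethyl with hydrogen on the oxygen, which turns methoxymethoxy into hydroxy, gives a number 9 percentage points lower from compound 3 to compound 4 (within the scatter). Set beside the only other example of this change, the result on the second core cannot be told apart from the result on the first: the same change on two cores in this assay, a number 0.5 percentage points lower (within the scatter) from compound 2 to compound 1 and a number 9 percentage points lower (within the scatter) from compound 3 to compound 4, 8.5 percentage points apart, within the scatter of two such steps. This shows that, across these two pairs, the change carried from one core to the other without a difference that can be read in this assay, but it does not show that the change is without effect on either core, that the two steps are truly equal, or that the same would hold on a third core, and a single tested concentration says nothing about potency.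

The compounds shown leave open how other groups on that oxygen, such as a methyl ether or an acetyl ester, would compare with the hydroxy and methoxymethoxy forms on these two cores. They also leave open how a primary amine, a carboxylic acid or a longer chain elsewhere in the series would read in this assay, alone or together with this change.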